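The source may hold more compounds than are shown below. What is called first, only, known or untested is meant among the compounds shown, and "the series" means these compounds.

In a functional assay on MCF7 cells (Homo sapiens) for antiproliferative activity, read by CCK-8 assay, with a stated time of 72 h (a lower number here means a stronger inhibitor of growth, a higher number a weaker inhibitor of growth), compound 1 `CCC1C(=O)N(C)c2cnc(-n3ccc4cc(F)ccc43)nc2N1c1ccn(C)n1` gives 24700 nM. On the same core, compound 2 `CCCNC(=O)c1ccc2c(ccn2-c2ncc3c(n2)N(c2ccn(C)n2)C(CC)C(=O)N3C)c1` gives 6420 nM and compound 3 `CCCCNC(=O)c1ccc2c(ccn2-c2ncc3c(n2)N(c2ccn(C)n2)C(CC)C(=O)N3C)c1` gives 8990 nM. Compound 3 therefore stands level with one neighbour and apart from the other: the chain change shows a 1.4-fold higher number from compound 2 to compound 3 (0.15 log units; within the scatter), whereas the exchange of fluoro for butylcarbamoyl shows a 2.7-fold lower number from compound 1 to compound 3 (0.44 log units; beyond the scatter). The exchange of fluoro for propylcarbamoyl is of similar modest size, with a 3.8-fold lower number from compound 1 to compound 2 (0.59 log units; beyond the scatter). Compound 4 `CCNC(=O)c1ccc2c(ccn2-c2ncc3c(n2)N(c2ccn(C)n2)C(CC)C(=O)N3C)c1` keeps the core and alters only the amide chain: hydrogen in place of ethyl on a saturated chain carbon, two bonds along the chain from an amide-type nitrogen, so that butyl becomes ethyl. Going by the values given here, the closest precedent is the measured chain change, a 1.4-fold higher number from compound 2 to compound 3 (0.15 log units; within the scatter), so no step beyond the scatter is expected here, though that precedent is a single pair. The expected step is a 1.3-fold lower number from compound 3 to compound 4 (0.11 log units; within the scatter) in this assay. Compound 4 is estimated at 7000 nM, within an expected range of 3500 nM to 14000 nM.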

Compound 4, concentration for 50% growth inhibition: 13200 nM
The estimate for compound 4 lay 1.9-fold (0.28 log units) below the measured number; the range from low to high includes it.
By their numbers in this assay, from the lowest: compounds 2, 3, 4 and 1 (each within the scatter of the next, the first and the last beyond it).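

In this assay, going by these compounds alone, trimming the amide chain to ethyl separates it only slightly from the butyl amide, with a 1.5-fold higher number from compound 3 to compound 4 (0.17 log units; within the scatter), but it gives the first chain step beyond the scatter, a 2.1-fold higher number from compound 2 to compound 4 (0.31 log units; beyond the scatter), so this position does respond to chain length, if modestly, and the response is not a steady trend across the three amides. Compound 4 also goes against the earlier picture in which a carbamoyl group in place of fluoro gave a step beyond the scatter, since ethylcarbamoyl shows only a 1.9-fold lower number from compound 1 to compound 4 (0.27 log units; within the scatter). Nothing given here accounts for these steps.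

From the compounds shown here alone, the three amides span a narrow range of chains, so the effect of a methyl amide, a pentyl chain or a branched isopropyl group remains open. So does the effect of a chain ending in an amine or a carboxylic acid.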